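Dropping the Bromo Group from Compound 3

The source may report more compounds than this note shows. Statements on the series, on what has been measured and on what is new or still open speak of the compounds shown alone.

Compound 3 `CNC(=O)c1cc(Oc2ccc(C(=O)/C=C/c3cccc(Br)c3)cc2)ccn1` gives 10400 nM in a functional assay on MCF7 cells (Homo sapiens) for cytotoxicity, read by MTT assay, with a stated time of 72 h (a higher number here means a weaker inhibitor, a lower number a stronger inhibitor), the lowest of the two numbers measured, while compound 2 `CNC(=O)c1cc(Oc2ccc(C(=O)/C=C/c3ccc(F)cc3Cl)cc2)ccn1` gives 21100 nM, the nearest value. Compound 1 `CNC(=O)c1cc(Oc2ccc(C(=O)/C=C/c3cccc([N+](=O)[O-])c3)cc2)ccn1` reaches only a limit of this assay, at > 50000 nM. Compound 4 `CNC(=O)c1cc(Oc2ccc(C(=O)/C=C/c3ccccc3)cc2)ccn1` differs from compound 3 by hydrogen in place of bromo on an aromatic carbon. Going by the values given here, no measured step removes a halogen outright; the closest comparisons are an at least 4.8-fold lower number from compound 1 to compound 3 (0.68 log units; beyond the scatter) and a 2.0-fold lower number from compound 2 to compound 3 (0.31 log units; beyond the scatter), both of which show that what sits on this ring shifts the result by modest amounts. Taking the bromo away from compound 3 is expected to weaken inhibition, estimated as a 2.1-fold higher number from compound 3 to compound 4 (0.33 log units; beyond the scatter). Compound 4 is therefore expected to give about 22000 nM, with a plausible range from 9000 nM to 50000 nM.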

Compound 4, half-maximal inhibitory concentration: 5960 nM
For compound 4 the middle estimate is 3.7-fold (0.57 log units) above the measured one, and the stated range ends above it.
By their numbers in this assay, from the lowest: compounds 4 and 3 (each within the scatter of the next); then compound 2. At a limit, above all of these: compound 1.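

In this assay, taking off the bromo gives a 1.7-fold lower number from compound 3 to compound 4 (0.24 log units; within the scatter), so the 3-bromophenyl cannot be told apart from the bare phenyl and the bromo is not needed at this position. The bare phenyl also beats a ring with two halogens, with a 3.5-fold lower number from compound 2 to compound 4 (0.55 log units; beyond the scatter). The nitro comparison, an at least 8.3-fold lower number from compound 1 to compound 4 (0.92 log units; beyond the scatter), is only a bound, as compound 1 stands at a limit: the limit of > 50000 nM in this assay, at which 1 of the 4 values shown sits.

Still open, from the compounds shown here alone, is whether an amine or a methoxy group on this ring would give a lower number than compound 4. Going by these compounds, whether a small group such as a methyl would do so also remains open.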